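Shortening the Acyl Chain on a Glutamate Receptor Modulator

This account rests on a few compounds, and the source may have more. Where it says the series, first, only, none or still open, it means among the compounds named here.

Three compounds sharing one core were measured in an assay on HEK293 cells for positive allosteric modulation of metabotropic glutamate receptor 2 (Rattus norvegicus), read by thallium flux, with a stated time of 2.5 min; a higher number here means that more compound is needed for the effect, a lower number that less compound is needed. Compound 1, `CCC(=O)c1ccc(OCCCCOc2cc(C(=O)O)ccc2OC)c(C)c1O`, gives 162 nM in this assay. Compound 2, `CCCC(=O)c1ccc(OCCCCOc2ccc(C(=O)O)cc2C)c(C)c1O`, gives 104 nM, and compound 3, `Cc1c(OCCCCOc2ccc(C(=O)O)cc2Cl)ccc(C(=O)CC(C)C)c1O`, gives 96 nM. Of the three numbers, that of compound 1 is the largest, yet its gaps to compound 2 and to compound 3 both fall within the usual scatter of repeated measurements, so the three values cannot be told apart with confidence.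

Compound 4, `COc1ccc(C(=O)O)cc1OCCCCOc1ccc(C(C)=O)c(O)c1C`, is not yet measured. It differs from compound 1 in a single place: hydrogen in place of methyl on a saturated chain carbon bound to a carbonyl carbon. The carbonyl itself and everything else in the molecule stay unchanged.

For the measured compounds named here, no pair of measured compounds differing in one place is available, so the size of this kind of step is unknown from the data. The values of compound 2 and compound 3, with their longer acyl chains, sit somewhat lower than that of compound 1, but those compounds also differ elsewhere, and all three lie within the scatter. The step from compound 1 to compound 4 is therefore expected to be a 1.4-fold higher number from compound 1 to compound 4 (0.13 log units; within the scatter), most likely no further than the scatter allows. Compound 4 is estimated to give 220 nM in this assay, with a range from 100 nM to 500 nM.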

Compound 4, half-maximal effective concentration: 1090 nM
The estimate for compound 4 lay 5.0-fold (0.70 log units) below the measured number, and the stated range ends below it.
By their numbers in this assay, from the lowest: compounds 3, 2 and 1 (each within the scatter of the next); then compound 4.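

In this assay, for the compounds shown here, cutting propanoyl back to acetyl gives a 6.7-fold higher number from compound 1 to compound 4 (0.83 log units; beyond the scatter) and marks the first step in this set that can be read at a single place. It shows that this position is sensitive to the change: losing one methyl on a saturated chain carbon bound to a carbonyl carbon, with no ring, hydrogen-bond donor, hydrogen-bond acceptor or net charge involved, is enough to carry the number beyond the scatter. The compounds shown offer no information on the cause of this step.

Going by these compounds, it remains open whether the same step would appear on the cores of compound 2 and compound 3, as neither has a partner that differs from it only at this chain. On these data alone, it also remains open how this position would respond to groups other than hydrogen and methyl, such as a fluorine, a hydroxyl or a cyclopropyl group on the same carbon.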